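This account rests on a few compounds, and the source may have more. Where it says the series, first, only, none or still open, it means among the compounds named here.

Compound 2 `Cc1nn(-c2ncnc3nc[nH]c23)c2c1C(C(=O)N(C)c1ccccc1)CC(=O)N2` stands at the higher end of the two numbers recorded so far: in a functional assay on HEK293 cells for agonist activity at G-protein coupled receptor 39 (Homo sapiens), read by scintillation proximity assay and inositol phosphate accumulation, with a stated time of 75 min, in the presence of a further agent that is not named here (a lower number here means that less compound is needed, a higher number that more compound is needed for the effect), compound 2 gives 32 nM, and its nearest neighbour is compound 1 `Cc1noc(C)c1COC1CC(=O)Nc2c1c(C)nn2-c1ncnc2nc[nH]c12`, which in this assay gives 5 nM. For the measured compounds named here, the single measured step is a 6.4-fold higher number from compound 1 to compound 2 (0.81 log units; beyond the scatter), the only one recorded.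

Compound 3 `Cc1nn(-c2ncnc3nc[nH]c23)c2c1C(OCc1ccccc1Cl)CC(=O)N2` has not been measured. It differs from compound 2 in one place: (2-chlorobenzyl)oxy in place of methyl(phenyl)carbamoyl on a saturated ring carbon. The step that bears on this change is a 6.4-fold higher number from compound 1 to compound 2 (0.81 log units; beyond the scatter), in which the group at the same saturated ring carbon went from (3,5-dimethyl-1,2-oxazol-4-yl)methoxy to methyl(phenyl)carbamoyl. Going by the values given here, compound 3 moves in the opposite direction, away from methyl(phenyl)carbamoyl and back to a methoxy-type substituent, (2-chlorobenzyl)oxy, whose aromatic ring is not the one carried by compound 1. A step toward the number of compound 1 is therefore expected, but a full return is not assumed, as the two oxy groups differ in their rings. Compound 3 is estimated at 10 nM, with a range of 3 nM to 40 nM. This expectation corresponds to a 3.2-fold lower number from compound 2 to compound 3 (0.51 log units; beyond the scatter) in this assay.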

Compound 3, half-maximal effective concentration: 2 nM
Beside the measured number, compound 3's estimate is 5.0-fold (0.70 log units) above it; measured number below the stated range.
By their numbers in this assay, from the lowest: compound 3; then compound 1; then compound 2.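

In this assay the saturated ring carbon accepts a change of ring on the oxygen-linked substituent: 2-chlorophenyl in place of 3,5-dimethyl-1,2-oxazol-4-yl gives a 2.5-fold lower number from compound 1 to compound 3 (0.40 log units; beyond the scatter) and, with the ether link held, the low number does not depend on the dimethyl-oxazole ring. Against the amide-linked group, the exchange of methyl(phenyl)carbamoyl for (2-chlorobenzyl)oxy gives a 16-fold lower number from compound 2 to compound 3 (1.20 log units; beyond the scatter), so both oxygen-linked compounds, compound 1 and compound 3, stand at lower numbers than compound 2, and none of the three compounds goes against this. No measurement on hand accounts for either step.

From the compounds shown here alone, the share of the chlorine in this gain stays open, since a plain benzyloxy group, without chlorine, would separate it from that of the benzyl ring itself. Also open, going by these compounds, is whether the ether oxygen matters, which a benzyl group joined through carbon alone would test, and how this saturated ring carbon responds to a chain ending in an amine or a carboxylic acid.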